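The source may hold more compounds than are shown below. What is called first, only, known or untested is meant among the compounds shown, and "the series" means these compounds.

Measured so far:
compound 1 `CC1(C)Cc2cc(N)ccc2O1` — > 100 mg/kg
compound 2 `Cc1c(C)c2c(c(C)c1N)CC(C)(CSc1ccc(F)cc1)O2` — 17.9 mg/kg

Among the measured compounds shown here, in a functional assay on the whole organism with Mus musculus as the target (on this read-out lower numbers stand for an effect already at smaller amounts and higher numbers for an effect only at larger amounts of compound), compound 2 gives 17.9 mg/kg, the only number so far. Compound 1 `CC1(C)Cc2cc(N)ccc2O1` gives only a limit in this assay, > 100 mg/kg; this is one of two values shown, and the other sits at the limit of > 100 mg/kg in this assay, at which 1 of the 2 values shown sits, so compound 2 stands alone as the one measured point. For the measured compounds named here, no step between measured compounds is available, as compounds 1 and 2 differ in more than one place.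

Compound 3 `Cc1c(C)c2c(c(C)c1N)CC(C)(CSCCC(=O)O)O2` is not yet measured in this assay. Compared with compound 2 the difference is 2-carboxyethyl in place of 4-fluorophenyl on a sulfur. A 4-fluorophenyl on the sulfur is replaced by a 2-carboxyethyl, a shorter, ring-free chain carrying a hydrogen-bond donor and acceptor.

Going by the values given here, with only one number in hand, the size of the step is a guess. The expectation is a shift towards higher doses, a step of a 2.2-fold higher number from compound 2 to compound 3 (0.35 log units; beyond the scatter) in this assay, somewhat beyond the usual scatter but not large. Compound 3 is therefore estimated at 40 mg/kg in this assay, within a range of 12 mg/kg to 150 mg/kg.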

Compound 3, dose for 50% inhibition: 43 mg/kg
Compound 3: the middle estimate sits 1.1-fold (0.03 log units) below what was measured; the range from low to high includes it.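

The position on the sulfur now has its first readable step in this assay: replacing 4-fluorophenyl with 2-carboxyethyl gives a 2.4-fold higher number from compound 2 to compound 3 (0.38 log units; beyond the scatter) as a modest change. With compound 3 at 43 mg/kg in this pair, a six-membered aromatic ring of carbon only on the sulfur is not needed for a measured dose in this assay, and a chain with no ring, carrying a hydrogen-bond donor and a hydrogen-bond acceptor, still gives a number rather than a limit. The data shown do not divide the step between the ring that leaves and the acid chain that enters, and nothing measured here accounts for its size.

A single pair cannot show whether the carboxylic acid itself matters or whether any group without the aromatic ring would give a similar number. The methyl ester or primary amide of the same chain, an unsubstituted phenyl on the sulfur, and a longer chain ending in a carboxylic acid would separate these possibilities.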